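The compounds below may be only part of what the source reports. "The series", "measured", "known", "first", "only" and "open" are said of these compounds alone.

Of the compounds shown here, three have so far been measured in a functional assay on SW1573 cells (Homo sapiens) for antiproliferative activity, read by sulforhodamine B assay, with a stated time of 48 h; on this read-out lower numbers stand for stronger inhibition of growth and higher numbers for weaker inhibition of growth. Compound 1 `C#CCO/C=C/C(=O)OC` gives only a limit in this assay, > 100000 nM, as the limit of > 100000 nM in this assay, at which 1 of the 3 values shown sits, records. Compound 2 `COC(=O)C#CC(CC(C)C)O/C=C/C(=O)OC` gives 380 nM in this assay, the lowest of the two numbers available. Within the data shown here, compound 3 `CC(C)C(C#CC(=O)OC(C)(C)C)O/C=C/C(=O)OC(C)(C)C` gives 4800 nM in this assay, a gap beyond the scatter; since compound 3 and compound 2 differ in several places at once, the two values show only that compound 3 sits well above compound 2.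

Compound 4 `COC(=O)C#CC(O/C=C/C(=O)OC)C(C)(C)C` has not yet been measured. It and compound 2 have the same atoms, joined differently: tert-butyl in place of isobutyl on a saturated chain carbon bound to an oxygen on an unsaturated carbon and a triple-bonded carbon. Among the measured compounds shown here, no measured pair in the set isolates this change, so nothing tells directly how this assay will answer it. The writer expects a modest rise in the number from compound 2 to compound 4, a 2.4-fold higher number from compound 2 to compound 4 (0.37 log units; beyond the scatter), possibly no larger than the scatter. Compound 4 is therefore estimated at 900 nM in this assay, within a range from 300 nM to 3000 nM.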

Compound 4, concentration for 50% growth inhibition: 3000 nM
Compound 4: the middle estimate sits 3.3-fold (0.52 log units) below what was measured; the range from low to high includes it.
By their numbers in this assay, from the lowest: compound 2; then compounds 4 and 3 (each within the scatter of the next). At a limit, above all of these: compound 1.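

Among these compounds, the pair gives the first step in the set that isolates a single change: tert-butyl in place of isobutyl on a saturated chain carbon bound to an oxygen on an unsaturated carbon and a triple-bonded carbon brings a 7.9-fold higher number from compound 2 to compound 4 (0.90 log units; beyond the scatter) in this assay. The two groups have the same heavy-atom count and neither carries a charge, so this position responds to how those carbons are joined, and isobutyl is the better of the two here. Nothing measured in the set gives a cause for this step.

Among the compounds shown here, only this one pair speaks to the position, so no trend can be read from it. On these data alone, whether a longer chain, a phenyl ring or an amine would be accepted there remains open, as does whether the step would hold with the methyl esters replaced by tert-butyl esters.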